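The compounds below may be only part of what the source reports. "The series", "measured", "known", "first", "only" and "open" are said of these compounds alone.

Measured so far in a functional assay on LS174T cells (Homo sapiens) for inhibition, with a stated time of 4 days, tested at 100 nM; on this read-out higher numbers stand for a stronger effect at the one concentration tested and lower numbers for a weaker effect:
- compound 1 `Fc1cccc(F)c1C#Cc1cnc2ccccc2c1`: 0%
- compound 2 `Fc1ccc2cc(C#Cc3c(F)cccc3F)cnc2c1`: 14.8%

Compound 1 stands lowest of the two numbers; its nearest neighbour is compound 2, reached by a number 14.8 percentage points higher from compound 1 to compound 2 (beyond the scatter), a step beyond the scatter.

Compound 3 `Fc1cccc(F)c1C#Cc1cnc2c(F)cccc2c1` is the next target. Relative to compound 1 it carries fluoro in place of hydrogen on an aromatic carbon, the new fluoro sitting on an aromatic carbon of the six-membered carbon-only ring within the fused system of two rings.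

For the measured compounds named here, only one measured step bears on this change: the same kind of fluoro-for-hydrogen exchange on the fused ring of compound 1, though at a different place, gave a number 14.8 percentage points higher from compound 1 to compound 2 (beyond the scatter). Because of a number 14.8 percentage points higher from compound 1 to compound 2 (beyond the scatter), a modest rise is expected for compound 3 as well, but with the position changed the size is uncertain and a result within the scatter cannot be excluded. The expected step is a number 10 percentage points higher from compound 1 to compound 3 (within the scatter). Compound 3 is estimated at 10% in this assay, with a range from 0% to 28%.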

Compound 3, a percentage reported as inhibition, at one concentration (the size of the read-out at that concentration, not a potency): 8.8%
The estimate for compound 3 lay 1.2 percentage points above the measured number, within the range that was stated.
By their numbers in this assay, from the lowest: compounds 1, 3 and 2 (each within the scatter of the next, the first and the last beyond it).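

In this assay, fluoro in place of hydrogen on an aromatic carbon of the six-membered aromatic ring of carbon only, ortho to a fused ring and meta to a fused ring, gives a number 8.8 percentage points higher from compound 1 to compound 3 (within the scatter). At this place the exchange cannot be told apart from no change, whereas the same kind of exchange at the place it occupies in compound 2 gave a number 14.8 percentage points higher from compound 1 to compound 2 (beyond the scatter), so a step beyond the scatter does not come with every fluoro on this ring. Nothing at hand accounts for this difference between the two places.

On these data alone, it stays open whether a methoxy group or an amine at this place would move the read-out beyond the scatter, and whether the fluoro groups of compound 2 and compound 3 would add up in one compound. The read-out at a single concentration also leaves the potency of all these compounds undefined.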